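This account rests on a few compounds, and the source may have more. Where it says the series, first, only, none or still open, it means among the compounds named here.

Of the compounds shown here, three have so far been measured in an ADME assay on HEK293 cells (Homo sapiens) for cytotoxicity, read by MTT assay, with a stated time of 72 h; on this read-out lower numbers stand for stronger inhibition and higher numbers for weaker inhibition. Within the data shown here, compound 1 `COc1ccc(OC)c(C2=C(c3cc(OC)c(OC)c(OC)c3)C(=O)CC2O[SiH2]C(C)(C)C)c1` is the only one to return a number: in this assay compound 1 gives 9.5 ug/mL. Compound 3 `COc1ccc(C2=C(c3cc(OC)c(OC)c(OC)c3)CC(O[SiH2]C(C)(C)C)C2=O)cc1[N+](=O)[O-]` reaches only a limit of the assay, and in this assay compound 3 gives > 100 ug/mL. Compound 2 `COc1ccc(C2=C(c3cc(OC)c(OC)c(OC)c3)CC(O)C2=O)cc1[N+](=O)[O-]` likewise stops at a limit, giving > 100 ug/mL in this assay. The change from compound 3 to compound 2 is a hydrogen atom in place of a group of 5 heavy atoms (4 carbon, 1 silicon; no ring), on an oxygen on a saturated carbon; the step it made, a step that the two limits leave unreadable from compound 3 to compound 2, has no readable size, since both values sit at the limit of > 100 ug/mL in this assay, at which 2 of the 3 values shown sit. The cores of compound 1 and compound 3 differ in more than one place, and that difference is not broken down here.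

Compound 4 `COc1ccc(OC)c(C2=C(c3cc(OC)c(OC)c(OC)c3)C(=O)CC2O)c1` has not yet been measured. It arises from compound 1 by the same change: a hydrogen atom in place of a group of 5 heavy atoms (4 carbon, 1 silicon; no ring), on an oxygen on a saturated carbon. Among the measured compounds shown here, the one earlier instance of this change, a step that the two limits leave unreadable from compound 3 to compound 2, yields no size, so the expectation for compound 4 rests mainly on compound 1 and its value of 9.5 ug/mL in this assay. For compound 4 the expected step is modest, a 2.1-fold higher number from compound 1 to compound 4 (0.32 log units; beyond the scatter). Compound 4 is therefore estimated at 20 ug/mL in this assay, with a range from 5 ug/mL to 80 ug/mL reflecting the uncertainty that the unreadable earlier step leaves.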

Compound 4, half-maximal inhibitory concentration: > 100 ug/mL
Compound 4 gave a limit, no number; the forecaster's own chance of this, stated with the estimate: 25%; middle value at least 5.0-fold (0.69 log units) away from the limit.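

Among these compounds, on the one core where the change can be sized, a hydrogen atom in place of the group of 5 heavy atoms (4 carbon, 1 silicon; no ring), on an oxygen on a saturated carbon, gives an at least 10-fold higher number from compound 1 to compound 4 (1.02 log units; beyond the scatter) in this assay, and the second value of that step is a limit of the assay, so the true size is not known. On the other core the step from compound 3 to compound 2 cannot be read, so the compounds shown do not tell whether the change acts there as it does on the core of compound 1, and compound 3 shows that carrying this group does not by itself bring a value inside the limit. One sized step on one core therefore gives no rule that travels between cores, and most of the series rests at one limit: the limit of > 100 ug/mL in this assay, at which 3 of the 4 values shown sit.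

What the compounds shown leave open is whether the number seen for compound 1 depends on this particular group, or whether a methyl or an acetyl group on the same oxygen would also give a number. They also leave open which of the several differences between the core of compound 1 and the core of compound 3 matters in this assay.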